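Swapping bromo for fluoro in a cytotoxicity series

The compounds below may be only part of what the source reports. "The series", "measured", "known", "first", "only" and "open" are said of these compounds alone.

Compound 1 `O=C(CN1CCN(C(=O)c2ccc(Br)cc2)CC1)N1CCN(CCCc2c[nH]c3ccccc23)CC1` and compound 2 `O=C(CN1CCN(C(=O)c2ccc(F)cc2)CC1)N1CCN(CCCc2c[nH]c3ccccc23)CC1` share one core and differ by fluoro in place of bromo on an aromatic carbon. In an ADME assay on HEK293 cells (Homo sapiens) for cytotoxicity, read by MTT assay, with a stated time of 72 h (a higher number here means a weaker inhibitor, a lower number a stronger inhibitor), compound 1 gives 71900 nM, and compound 2 gives 141000 nM; the step between them is a 2.0-fold higher number from compound 1 to compound 2 (0.29 log units; within the scatter). Compound 3 `O=C(CN1CCN(C(=O)c2cccc(Br)c2)CC1)N1CCN(CCCc2c[nH]c3ccc(F)cc23)CC1` gives 40600 nM in this assay; how its core differs from the core of compound 1 is not broken down here. Compound 4 `O=C(CN1CCN(C(=O)c2cccc(F)c2)CC1)N1CCN(CCCc2c[nH]c3ccc(F)cc23)CC1` has not yet been measured and differs from compound 3 by fluoro in place of bromo on an aromatic carbon. In compound 2 the group sits para to a large group, in compound 4 meta to a large group, so this is the same kind of change, not the same one. Expected is a 1.7-fold higher number from compound 3 to compound 4 (0.24 log units; within the scatter) because the earlier swap gave a 2.0-fold higher number from compound 1 to compound 2 (0.29 log units; within the scatter). Compound 4 is therefore estimated at 70000 nM, likely between 30000 nM and 160000 nM.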

Compound 4, half-maximal inhibitory concentration: 83000 nM
The estimate for compound 4 lay 1.2-fold (0.07 log units) below the measured number; measured number inside the range.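

In this assay the swap of bromo for fluoro gives a 2.0-fold higher number from compound 3 to compound 4 (0.31 log units; beyond the scatter) as 3-bromophenyl becomes 3-fluorophenyl, a modest change. Among these compounds, this is only two pairs, and they differ in where the swap sits, so it gives no general rule for the series and does not explain why the number moves. Still, the step carried over from one core to the other with its size intact: the same change on two cores in this assay, a 2.0-fold higher number (0.29 log units; within the scatter) from compound 1 to compound 2 and a 2.0-fold higher number (0.31 log units; beyond the scatter) from compound 3 to compound 4, 1.0-fold (0.02 log units) apart, within the scatter of two such steps.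

Left open is whether a chloro, a methoxy or an amine in the same place would behave like fluoro. Also open, going by these compounds, is whether the step would hold on a third core.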